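Swapping a Pyridinyl for a Pyrimidinyl on the Core

A few compounds are considered here, and "the series" means these few. Any claim that something is new, unique, unknown or untested is made for them only; others in the source may bear on it.

Compound 2 `Cc1nc(C(F)(F)F)ccc1C(=O)Nc1ccc(Cl)c(-c2cccnc2)c1` gives the highest number of the two measured in an assay on C3H 10T1/2 cells for inhibition of Sonic hedgehog protein (Mus musculus), read by a luciferase reporter (on this read-out lower numbers stand for stronger inhibition and higher numbers for weaker inhibition), namely 10000 nM, while compound 1 `Cc1nc(C(F)(F)F)ccc1C(=O)Nc1ccc(Cl)c(-c2nc3ccccc3n2C)c1` gives 9 nM; the step of a 1100-fold higher number from compound 1 to compound 2 (3.05 log units; beyond the scatter) is large. Compound 3 `Cc1nc(C(F)(F)F)ccc1C(=O)Nc1ccc(Cl)c(-c2ncccn2)c1` carries the change (pyrimidin-2-yl in place of pyridin-3-yl on an aromatic carbon). No measured step bears directly on this exchange; the only step shown concerns a different group at the same position, so the expectation rests on compound 2 alone and a step of no change at the digits printed from compound 2 to compound 3 (within the scatter), essentially none beyond the scatter, is expected. Compound 3 is therefore estimated at 10000 nM, ranging from 2500 nM to 30000 nM.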

Compound 3, half-maximal inhibitory concentration: 8000 nM
For compound 3 the middle estimate is 1.3-fold (0.10 log units) above the measured one, and the stated range covers the measured number.
By their numbers in this assay, from the lowest: compound 1; then compounds 3 and 2 (each within the scatter of the next).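

In this assay, pyrimidin-2-yl in place of pyridin-3-yl on this aromatic carbon gives a 1.3-fold lower number from compound 2 to compound 3 (0.10 log units; within the scatter) and so a second ring nitrogen does not separate the two groups here. Pyrimidin-2-yl in place of 1-methyl-1H-benzimidazol-2-yl gives an 890-fold higher number from compound 1 to compound 3 (2.95 log units; beyond the scatter) and so neither six-membered aromatic ring comes near compound 1. Nothing measured here explains these steps.

On these data alone, whether a phenyl ring or a benzimidazol-2-yl group without the methyl on this aromatic carbon would come closer to compound 1 stays open.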